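A few compounds are considered here, and "the series" means these few. Any claim that something is new, unique, unknown or untested is made for them only; others in the source may bear on it.

Measured so far:
Compound 1, `Cc1c(OCCCCOc2ccccc2C(=O)O)ccc(C(=O)CC2CCCC2)c1O`: 335 nM
Compound 2, `CCC(=O)c1ccc(OCCCCOc2ccc(F)c(C(=O)O)c2)c(C)c1O`: 124 nM

Both compounds were tested in an assay on HEK293 cells for positive allosteric modulation of metabotropic glutamate receptor 2 (Rattus norvegicus), read by thallium flux, with a stated time of 2.5 min; on this read-out lower numbers stand for an effect already at smaller amounts and higher numbers for an effect only at larger amounts of compound. Compound 1 gives 335 nM there, and compound 2 gives 124 nM, the lower of the two numbers; the gap between them lies beyond the usual scatter, so compound 2 stands as the better of this pair. The two differ in more than one place, though, so no single change can be credited for that gap.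

Compound 3, `Cc1c(OCCCCOc2ccc(F)c(C(=O)O)c2)ccc(C(=O)CC2CCCC2)c1O`, has not yet been measured. Relative to compound 2 the change is cyclopentyl in place of methyl on a saturated chain carbon bound to a carbonyl carbon. Among the measured compounds shown here, no measured pair isolates this change, so its effect cannot be read off from these data. Compound 1 carries the same cyclopentyl group but a differently substituted acid ring, so its value alone does not settle the question. The expected step is a 1.2-fold higher number from compound 2 to compound 3 (0.08 log units; within the scatter), small and in no settled direction, likely within the scatter. For compound 3 the estimated value in this assay is 150 nM, with a range from 50 nM to 450 nM.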

Compound 3, half-maximal effective concentration: 699 nM
Compound 3: the middle estimate sits 4.7-fold (0.67 log units) below what was measured; measured number above the stated range.
By their numbers in this assay, from the lowest: compound 2; then compound 1; then compound 3.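

Cyclopentyl in place of methyl on a saturated chain carbon bound to a carbonyl carbon gives a 5.6-fold higher number from compound 2 to compound 3 (0.75 log units; beyond the scatter) in this assay and so puts a first measured size on a change at this position: with the 3-carboxy-4-fluorophenyl group held constant, the cyclopentyl compound needs a larger amount for its effect. With cyclopentyl held constant instead, 3-carboxy-4-fluorophenyl in place of 2-carboxyphenyl on the oxygen gives a 2.1-fold higher number from compound 1 to compound 3 (0.32 log units; beyond the scatter) and shows that this ring, though present in compound 2, brings no gain in the cyclopentyl series. Nothing measured here explains either step.

The compounds shown do not reveal whether the ring change would run the same way with methyl at the first position, which would take the compound with 2-carboxyphenyl and the propanoyl group of compound 2 to tell. They also leave open how the number moves with groups of intermediate shape in the same place, such as ethyl or isopropyl, and so whether the rise is gradual or tied to the cyclopentyl ring itself.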